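The compounds below may be only part of what the source reports. "The series", "measured", "known", "first", "only" and "open" are said of these compounds alone.

Measured compounds:
- compound 1 `COc1ccccc1/C=N/Nc1nc2ccccc2nc1Cc1ccccc1` gives 790000 nM
- compound 2 `COc1cc(/C(C)=N/Nc2nc3ccccc3nc2Cc2ccccc2)cc(OC)c1OC` gives 260000 nM

Both values come from an assay on isolated protein for inhibition of Amine oxidase [flavin-containing] B (Homo sapiens), read by spectrophotometry; on this read-out lower numbers stand for stronger inhibition and higher numbers for weaker inhibition. Of the two numbers, compound 1 holds the higher one, and compound 2, with its lower value, stands apart from it by a gap that lies beyond the usual scatter of this assay. Compound 2 differs from compound 1 in more than one place, so nothing can be read from the pair about any single change.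

Compound 3 `Clc1ccc(/C=N/Nc2nc3ccccc3nc2Cc2ccccc2)cc1` differs from compound 1 in one place: 4-chlorophenyl in place of 2-methoxyphenyl on a carbon with a double bond to nitrogen. For the measured compounds named here, no measured pair in this set isolates such a swap, so there is no step on which to rest a direction. The account therefore expects a small step, a 1.6-fold lower number from compound 1 to compound 3 (0.20 log units; within the scatter), pointing slightly toward a lower number but with the full scatter of this assay left open on either side. Compound 3 is estimated to give 500000 nM, within a range from 150000 nM to 1500000 nM.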

Compound 3, half-maximal inhibitory concentration: 84000 nM
Estimate against measurement, compound 3: 6.0-fold (0.77 log units) above; measured number outside the range, below it.
By their numbers in this assay, from the lowest: compound 3; then compound 2; then compound 1.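

Putting 4-chlorophenyl in place of 2-methoxyphenyl on a carbon with a double bond to nitrogen gives a 9.4-fold lower number from compound 1 to compound 3 (0.97 log units; beyond the scatter) in this assay, a step beyond the scatter. It shows that the number responds to a change at this position alone, which the earlier pair, differing in more than one place, could not show. The step changes both the group carried on the phenyl ring and its number in the name, so it cannot tell these two changes apart, and nothing available bears on why the number drops.

The compounds shown leave open whether 4-methoxyphenyl or 2-chlorophenyl would stand nearer to compound 1 or to compound 3, a comparison that would separate the effect of the group from that of its place on the ring. They also leave open how an amine or a carboxylic acid in place of the chlorine of 4-chlorophenyl would read in this assay, and whether the step from compound 1 to compound 3 would carry over to other groups at this position.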